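A few compounds are considered here, and "the series" means these few. Any claim that something is new, unique, unknown or untested is made for them only; others in the source may bear on it.

Measured compounds:
- compound 1, `Cc1cccc(NC(=O)CN2CCN(c3cccc4ccccc34)CC2)c1`: 2520 nM
- compound 2, `Cc1cccc(NC(=O)CN2CCN(c3ccc(Cl)cn3)CC2)c1`: 4700 nM
- compound 3, `Cc1ccc(C2CCN(CC(=O)Nc3cccc(C)c3)CC2)nc1`: 453 nM

The three measured compounds share an acetamide linker to the same aryl amine and differ in the ring system on the far side. In a functional assay on cells for antagonist activity at D(4) dopamine receptor (Homo sapiens), read by TR-FRET and cAMP accumulation, with a stated time of 30 min (on this read-out lower numbers stand for stronger inhibition and higher numbers for weaker inhibition), compound 3 gives the lowest of the three numbers; compound 1 stands a step above it that is beyond the usual scatter, and compound 2 stands further still, also beyond the scatter. Compound 3 is therefore the most potent of the three on these figures.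

Compound 4, `Cc1ccc(C2CCN(CC(=O)Nc3cccc(C)c3)CC2)cc1`, is not yet measured. It differs from compound 3 in one place: 4-methylphenyl in place of 5-methylpyridin-2-yl on a saturated ring carbon. Among the compounds with values here, no measured pair here isolates this particular exchange, so its size cannot be read from the data. The author expects the step from compound 3 to compound 4, a 1.3-fold lower number from compound 3 to compound 4 (0.11 log units; within the scatter), to stay within the scatter, with at most a slight drift toward a lower number. On that basis compound 4 is estimated at 350 nM in this assay, with a range from 120 nM to 1200 nM.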

Compound 4, half-maximal inhibitory concentration: 3060 nM
For compound 4 the middle estimate is 8.7-fold (0.94 log units) below the measured one, and the stated range ends below it.
By their numbers in this assay, from the lowest: compound 3; then compounds 1, 4 and 2 (each within the scatter of the next).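

In this assay, the exchange gives a 6.8-fold higher number from compound 3 to compound 4 (0.83 log units; beyond the scatter), which shows that this place on the saturated ring carbon is sensitive to the identity of the aromatic ring it carries. The two groups match in their count of heavy atoms and in ring size, and they differ in the nitrogen and the single hydrogen-bond acceptor of the 5-methylpyridin-2-yl group, which the 4-methylphenyl group lacks. This pair thus links the lower number to that one exchange of atoms, but nothing available here explains the step.

Going by these compounds, it remains open how a plain pyridin-2-yl group, or a methoxy group in place of the methyl, would stand in this assay. On these data alone, whether exchanging that nitrogen for carbon would have a similar effect on another core also remains open.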